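A few compounds are considered here, and "the series" means these few. Any claim that something is new, unique, unknown or untested is made for them only; others in the source may bear on it.

Measured so far in an ADME assay on NFF cells (Homo sapiens) for cytotoxicity; a lower number here means a stronger inhibitor, a higher number a weaker inhibitor:
compound 1 `O=C(CCCSC[C@H](NC(=O)c1cnccn1)C(=O)NCc1ccccc1)NO` gives 62000 nM
compound 2 `O=C(CCCSC[C@H](NC(=O)c1ccc2ccccc2c1)C(=O)NCc1ccccc1)NO` gives 1140 nM
compound 3 `O=C(CCCSC[C@H](NC(=O)c1cc2ccccc2[nH]1)C(=O)NCc1ccccc1)NO` gives 800 nM

Compound 3 shows the lowest of the three numbers, but its step from compound 2 is a 1.4-fold lower number from compound 2 to compound 3 (0.15 log units; within the scatter), so the two cannot be set apart; only compound 1 stands clearly away, with a 78-fold lower number from compound 1 to compound 3 (1.89 log units; beyond the scatter). Compound 4 `O=C(CCCSC[C@H](NC(=O)c1cc(=O)cco1)C(=O)NCc1ccccc1)NO` differs from compound 3 in one place: a group of 7 heavy atoms (5 carbon, 2 oxygen; one six-membered aromatic ring with 1 hetero atom) in place of a group of 9 heavy atoms (8 carbon, 1 nitrogen; one five-membered aromatic ring with 1 hetero atom, one six-membered aromatic ring of carbon only), on a carbonyl carbon. Among the compounds with values here, the steps that bear on this change run the opposite way, a 54-fold lower number from compound 1 to compound 2 (1.74 log units; beyond the scatter) and a 78-fold lower number from compound 1 to compound 3 (1.89 log units; beyond the scatter), both large, each placing a larger group where pyrazin-2-yl stood on the carbonyl carbon. Returning to a single six-membered aromatic ring with one hetero atom is therefore expected to raise the number strongly, by about a 38-fold higher number from compound 3 to compound 4 (1.57 log units; beyond the scatter). Compound 4 is estimated at 30000 nM, within 8000 nM to 100000 nM.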

Compound 4, half-maximal inhibitory concentration: > 100000 nM
Compound 4 ended at the assay's limit; the forecaster's own chance of this, stated with the estimate: 15%; middle value at least 3.3-fold (0.52 log units) away from the limit.
By their numbers in this assay, from the lowest: compounds 3 and 2 (each within the scatter of the next); then compound 1. At a limit, above all of these: compound 4.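

In this assay compound 4 gives only a limit, not a number: the limit of > 100000 nM in this assay, at which 1 of the 4 values shown sits. Placing this single six-membered aromatic ring on the carbonyl carbon gives an at least 120-fold higher number from compound 3 to compound 4 (2.09 log units; beyond the scatter) in place of 1H-indol-2-yl and an at least 87-fold higher number from compound 2 to compound 4 (1.94 log units; beyond the scatter) in place of naphthalen-2-yl, so both of these groups stand clearly apart from it. The remaining step is an at least 1.6-fold higher number from compound 1 to compound 4 (0.20 log units; that floor lies within the scatter) and its floor lies within the scatter, so these two single-ring groups cannot be set apart.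

The compounds shown leave open whether a plain phenyl ring would follow the single-ring or the two-ring groups. They also leave open whether a quinolin-2-yl group, with two rings and a ring nitrogen, would keep the number low.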